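Series notes: the step from compound 3 to compound 4

This account rests on a few compounds, and the source may have more. Where it says the series, first, only, none or still open, it means among the compounds named here.

Compound 1 `O=C(CCCCCCc1ccccc1)c1nc(Br)co1`, compound 2 `CC(=O)c1cnc(C(=O)CCCCCCc2ccccc2)o1` and compound 3 `CN(C)C(=O)c1cnc(C(=O)CCCCCCc2ccccc2)o1` share one core and differ only in the group on an aromatic carbon. In an assay on HEK-293T cells for inhibition of diacylglycerol lipase-alpha (Homo sapiens), read by colorimetric assay (on this read-out higher numbers stand for weaker inhibition and lower numbers for stronger inhibition), compound 1 gives > 10000 nM, a limit of the assay and not a number. Compound 2 in this assay gives > 10000 nM, again only a limit. Compound 3 in this assay gives > 10000 nM, likewise a limit. For the measured compounds named here, the single measured step, a step that the two limits leave unreadable from compound 2 to compound 3, is unreadable since (the limit of > 10000 nM in this assay, at which 3 of the 3 values shown sit). Compound 4 `CSc1cnc(C(=O)CCCCCCc2ccccc2)o1` differs from compound 3 by methylsulfanyl in place of dimethylcarbamoyl on an aromatic carbon. Going by the values given here, no measured step bears on this change, and the values shown give no direction. Compound 4 is expected to give 15000 nM in this assay, within 3000 nM to 100000 nM. The expected step that the limit leaves unreadable from compound 3 to compound 4 is estimated to stay within the scatter.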

Compound 4, half-maximal inhibitory concentration: > 10000 nM
Compound 4 gave a limit, no number (the forecaster's own chance of this, stated with the estimate: 80%); the middle value is on the limit's open side.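

In this assay compound 4 gives > 10000 nM as a limit and not a number. Its steps from compound 1, compound 2 and compound 3 cannot be read: the limit of > 10000 nM in this assay, at which 4 of the 4 values shown sit.

The compounds shown leave open which group on the aromatic carbon, if any, would give a value inside the readable range.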